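Swapping the pyridine group on compound 2

This account rests on a few compounds, and the source may have more. Where it says the series, first, only, none or still open, it means among the compounds named here.

Compound 2 `O=[N+]([O-])c1ccc(C2=NOC(c3ccc(N4CCN(Cc5ccc(F)nc5)CC4)cc3)C2)o1` stands only at a limit in an ADME assay on HeLa cells (Homo sapiens) for cytotoxicity, read by MTT assay, with a stated time of 96 h; a lower number here means a stronger inhibitor, a higher number a weaker inhibitor: there compound 2 gives > 50000 nM, a limit of the assay rather than a number. Compound 1 `COc1ccc(CN2CCN(c3ccc(C4CC(c5ccc([N+](=O)[O-])o5)=NO4)cc3)CC2)cn1` likewise gives a limit, > 50000 nM, in this assay. The step that the two limits leave unreadable from compound 1 to compound 2 therefore cannot be read, and the limit of > 50000 nM in this assay, at which 2 of the 2 values shown sit, shows that both values sit at that limit. Compound 3 `O=[N+]([O-])c1ccc(C2=NOC(c3ccc(N4CCN(Cc5ccccn5)CC4)cc3)C2)o1` differs from compound 2 by pyridin-2-yl in place of 6-fluoropyridin-3-yl on a saturated chain carbon bound to an amine nitrogen in a ring. Going by the values given here, no measured step reads clearly on such a change, so the expected step of a number no higher from compound 2 to compound 3 (the limit leaves the size open) is none beyond the scatter. Compound 3 is thus expected to give 50000 nM, between 25000 nM and 100000 nM, most likely again only a limit.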

Compound 3, half-maximal inhibitory concentration: > 50000 nM
Compound 3 gave a limit, no number; the forecaster's own chance of this, stated with the estimate: 85%; the middle value lies on the limit itself.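

Compound 3 gives > 50000 nM in this assay, again a limit and not a number. No step among compound 1, compound 2 and compound 3 can therefore be read: the limit of > 50000 nM in this assay, at which 3 of the 3 values shown sit.

From the compounds shown here alone, whether these swaps of the pyridine group change the true values at all stays open.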